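The compounds below may be only part of what the source reports. "The series", "measured", "known", "first", "only" and "open" are said of these compounds alone.

Measured compounds:
- compound 1 `O=[N+]([O-])c1ccc(NCc2ccccc2O)cc1`: "not active" (no number reported)
- compound 2 `Oc1ccccc1CNc1ccc(N2CCCC2)cc1`: "not active" (no number reported)
- compound 3 `Oc1ccccc1CNc1ccc(-c2ccc(Cl)cc2)cc1`: 2390 nM

Going by the values given here, in a functional assay on Jurkat cells (Homo sapiens) for activation, with a stated time of 24 h (on this read-out lower numbers stand for an effect already at smaller amounts and higher numbers for an effect only at larger amounts of compound), compound 3 is the only member of the series with a reported number; compound 1 and compound 2 are reported without one. Compound 3 therefore stands alone, with nothing to rank it against.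

Compound 4 `Oc1ccccc1CNc1ccc(-c2cccc(F)c2)cc1` differs from compound 3 by 3-fluorophenyl in place of 4-chlorophenyl on an aromatic carbon. Among the compounds with values here, no step between two measured compounds is available to calibrate this change. Given that compound 3 gives 2390 nM in this assay, compound 4 is expected to sit near that number or somewhat weaker, a step of a 1.7-fold higher number from compound 3 to compound 4 (0.22 log units; within the scatter) that may or may not exceed the scatter. The estimate for compound 4 is 4000 nM, with a range from 1500 nM to 15000 nM, and a fair chance that only a limit is reported.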

Compound 4, half-maximal effective concentration: 2020 nM
Compound 4: middle estimate off by 2.0-fold (0.30 log units), on the high side; the measured number falls inside the stated range.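

In this assay, 3-fluorophenyl in place of 4-chlorophenyl on this aromatic carbon gives a 1.2-fold lower number from compound 3 to compound 4 (0.07 log units; within the scatter), so the two groups cannot be told apart on this read-out. Compound 3 now has a measured neighbour, and a number at this position is not confined to a single aryl group. Nothing on hand accounts for this result.

The step swaps the halogen and its place on the ring together, so neither is read alone. As far as these compounds go, whether plain phenyl, or a carboxylic acid or an amine on that ring, keeps a number remains open.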